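This account rests on a few compounds, and the source may have more. Where it says the series, first, only, none or still open, it means among the compounds named here.

Going by the values given here, compound 2 `CC(C)n1cc(-c2cc(C(O)(C(F)(F)F)C(F)(F)F)cnc2N2CCN(S(=O)(=O)c3ccc(N)nc3)CC2)cn1` holds the only definite number in an ADME assay (liver) for metabolic stability, with Liver microsome (Homo sapiens) as the target, using microsomes and NADPH, with a stated time of 30 min, tested at 1 uM (on this read-out lower numbers stand for slow clearance and higher numbers for fast clearance), within this set: compound 2 gives 38 mL.min-1.g-1. Compound 1 `Nc1ccc(S(=O)(=O)N2CCN(c3ncc(C(O)(C(F)(F)F)C(F)(F)F)cc3C#CC3CC3)CC2)cn1` returns only a limit of the assay in this assay, namely < 14 mL.min-1.g-1. Among the compounds with values here, the one measured step, an at least 2.7-fold higher number from compound 1 to compound 2 (0.43 log units; beyond the scatter), came with 1-isopropyl-1H-pyrazol-4-yl in place of 2-cyclopropylethynyl on an aromatic carbon. Compound 3 `CS(=O)(=O)c1ccc(-c2cc(C(O)(C(F)(F)F)C(F)(F)F)cnc2N2CCN(S(=O)(=O)c3ccc(N)nc3)CC2)cc1` differs from compound 2 by 4-(methylsulfonyl)phenyl in place of 1-isopropyl-1H-pyrazol-4-yl on an aromatic carbon. That measured step does not touch the entering group, so it gives no direction for this change. The expected step from compound 2 to compound 3 is a 1.3-fold lower number from compound 2 to compound 3 (0.10 log units; within the scatter), within the scatter. In this assay, compound 3 is estimated at 30 mL.min-1.g-1, in a range from 12 mL.min-1.g-1 to 75 mL.min-1.g-1.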

Compound 3, intrinsic clearance in microsomes: 32 mL.min-1.g-1
Compound 3: the middle estimate sits 1.1-fold (0.03 log units) below what was measured; the range from low to high includes it.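

In this assay, a six-membered aromatic ring carrying methylsulfonyl on this aromatic carbon reads like the five-membered ring of the isopropyl pyrazole group, with a 1.2-fold lower number from compound 2 to compound 3 (0.07 log units; within the scatter). The 4-(methylsulfonyl)phenyl group also gives an at least 2.2-fold higher number from compound 1 to compound 3 (0.35 log units; beyond the scatter), so the higher number seen against 2-cyclopropylethynyl is not tied to the five-membered aromatic ring. The figure for compound 1 is a limit of the assay: the limit of < 14 mL.min-1.g-1 in this assay, at which 1 of the 3 values shown sits.

The compounds shown leave open whether an aromatic ring as such separates these groups from 2-cyclopropylethynyl. They also leave open whether a plain phenyl or a small amine on this carbon would read with compound 1 or with compound 3.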